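The compounds below may be only part of what the source reports. "The series", "measured", "known", "first", "only" and "open" are said of these compounds alone.

Compound 1 `Nc1ccccc1NC(=O)c1ccc(Cn2cc(-c3ccc(NC(=O)NCc4cccnc4)cc3)nn2)cc1`: in a functional assay on MDA-MB-231 cells (Homo sapiens) for cytotoxicity, read by MTT assay, with a stated time of 72 h (a lower number here means a stronger inhibitor, a higher number a weaker inhibitor), compound 1 gives > 100000 nM, which is a limit of the assay and not a number.
Compound 2 `Nc1ccccc1NC(=O)c1ccc(NC(=O)NCc2cccnc2)cc1`: in this assay compound 2 gives > 100000 nM, again a limit and not a number.

Among the measured compounds shown here, compound 2 therefore stands at the limit of > 100000 nM in this assay, at which 2 of the 2 values shown sit, so no measured step exists here to guide an estimate. Compound 3 `Nc1ccccc1NC(=O)c1ccc(NC(=O)NCc2ccc(Cl)nc2)cc1` differs from compound 2 by chloro in place of hydrogen on an aromatic carbon. With only limits at hand, the expected step that the limit leaves unreadable from compound 2 to compound 3 is none beyond the scatter, and compound 3 is expected to remain weak in this assay, at an estimated 150000 nM with a range from 30000 nM to 600000 nM.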

Compound 3, half-maximal inhibitory concentration: 34000 nM
Estimate against measurement, compound 3: 4.4-fold (0.64 log units) above, and the stated range covers the measured number.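

In this assay, the change from pyridin-3-yl to 6-chloropyridin-3-yl gives an at least 2.9-fold lower number from compound 2 to compound 3 (0.46 log units; beyond the scatter), so a substituent at this place on the ring can shift the read-out. Compound 3 is the only compound shown with a measured number, 34000 nM, rather than a limit. As far as these compounds go, the full size of the step stays unknown, as compound 2 has only a limit.

Whether chloro is special here stays open, since no other group, such as methyl, methoxy or an amine, is shown at this place. Also open, from the compounds shown here alone, is whether chloro would change the read-out of the larger compound 1.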